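This account rests on a few compounds, and the source may have more. Where it says the series, first, only, none or still open, it means among the compounds named here.

Of the compounds shown here, three sharing one core have been tested in a functional assay on MGC-803 cells (Homo sapiens) for inhibition, read by MTT assay, with a stated time of 72 h; on this read-out higher numbers stand for weaker inhibition and lower numbers for stronger inhibition. Compound 1 `N#Cc1c(Nc2cccc(C(F)(F)F)c2)nc(SCc2cn(Cc3ccccc3Cl)nn2)nc1-c1ccccc1` gives 22800 nM. Compound 2 `N#Cc1c(Nc2cccc([N+](=O)[O-])c2)nc(SCc2cn(Cc3ccccc3Cl)nn2)nc1-c1ccccc1` gives 43100 nM. Compound 3 `N#Cc1c(Nc2ccc(F)cc2)nc(SCc2cn(Cc3ccccc3Cl)nn2)nc1-c1ccccc1` gives 8740 nM, the lowest of the three numbers. The step of a 2.6-fold lower number from compound 1 to compound 3 (0.42 log units; beyond the scatter) and the step of a 4.9-fold lower number from compound 2 to compound 3 (0.69 log units; beyond the scatter) both lie beyond the scatter, whereas the step of a 1.9-fold higher number from compound 1 to compound 2 (0.28 log units; within the scatter) does not. Compound 4 `N#Cc1c(Nc2ccccc2)nc(SCc2cn(Cc3ccccc3Cl)nn2)nc1-c1ccccc1` has not yet been measured; it differs from compound 3 by hydrogen in place of fluoro on an aromatic carbon. Within the data shown here, no measured step removes a single fluoro in this way: the two steps that reach compound 3 exchanged the whole ring on the nitrogen, with trifluoromethyl or nitro leaving, and were only modest. Because the step of a 2.6-fold lower number from compound 1 to compound 3 (0.42 log units; beyond the scatter) and the step of a 4.9-fold lower number from compound 2 to compound 3 (0.69 log units; beyond the scatter) were modest even for those larger exchanges, the expected step of a 1.3-fold higher number from compound 3 to compound 4 (0.10 log units; within the scatter) is small and may fall within the scatter in either direction. Compound 4 is therefore estimated at 11000 nM, with a range from 4500 nM to 27000 nM.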

Compound 4, half-maximal inhibitory concentration: > 64000 nM
Compound 4 gave a limit, no number; the forecaster's own chance of this, stated with the estimate: 5%; middle value at least 5.8-fold (0.76 log units) from the limit.
By their numbers in this assay, from the lowest: compound 3; then compounds 1 and 2 (each within the scatter of the next). At a limit, above all of these: compound 4.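

Compound 4 sits at a limit of the assay and gives no number: the limit of > 64000 nM in this assay, at which 1 of the 4 values shown sits. Taking away one fluoro, para to a large group, gives an at least 7.3-fold higher number from compound 3 to compound 4 (0.86 log units; beyond the scatter), so a single atom at this position moves the number at least as far as the whole-ring exchanges did. The bare phenyl ring also compares poorly with the other substituted rings: there is an at least 2.8-fold higher number from compound 1 to compound 4 (0.44 log units; beyond the scatter), whereas an at least 1.4-fold higher number from compound 2 to compound 4 (0.17 log units; that floor lies within the scatter) does not separate the nitro compound from it.

From the compounds shown here alone, whether chloro, methoxy or an amine in place of the fluoro would keep the number as low as in compound 3 remains open. So does whether any group on this ring could take it lower still.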